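The source may hold more compounds than are shown below. What is called first, only, known or untested is meant among the compounds shown, and "the series" means these compounds.

Compound 1, `O=c1[nH]cnc2c1c(-c1cccs1)cn2[C@@H]1O[C@H](CO)[C@@H](O)[C@H]1O`, and compound 2, `O=c1[nH]cnc2c1c(-c1ccoc1)cn2[C@@H]1O[C@H](CO)[C@@H](O)[C@H]1O`, share one core and differ only in the aromatic group attached to it. In a functional assay on HepG2 cells (Homo sapiens) for antiproliferative activity, read by XTT assay, with a stated time of 72 h (a higher number here means a weaker inhibitor, a lower number a stronger inhibitor), compound 1 reaches only a limit of the assay, > 20000 nM. In this assay, among the compounds with values here, compound 2 gives 12100 nM, the only numerical value among the two measured compounds. Within the data shown here, the one measured step, an at least 1.6-fold lower number from compound 1 to compound 2 (0.21 log units; that floor lies within the scatter), rests on the limit of > 20000 nM in this assay, at which 1 of the 2 values shown sits, and so gives no firm direction. Compound 3, `O=c1[nH]cnc2c1c(-c1ccccc1)cn2[C@@H]1O[C@H](CO)[C@@H](O)[C@H]1O`, takes the next step from compound 2: phenyl in place of furan-3-yl on an aromatic carbon. Among the measured compounds shown here, no measured step bears directly on this change, so compound 3 is expected to stay in the same weak range as compound 2, with no step beyond the scatter in this assay; the expected step is a 1.2-fold higher number from compound 2 to compound 3 (0.09 log units; within the scatter). Compound 3 is therefore estimated at 15000 nM in this assay, in the range 5000 nM to 45000 nM.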

Compound 3, half-maximal inhibitory concentration: > 20000 nM
Compound 3: a limit, no number; the forecaster's own chance of this, stated with the estimate: 40%; at least 1.3-fold (0.12 log units) between middle value and limit.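

In this assay, phenyl on this aromatic carbon ends at a limit and not at a number, as thiophen-2-yl did, so furan-3-yl remains the only one of the three groups shown with a numerical value. The change from furan-3-yl to phenyl gives an at least 1.6-fold higher number from compound 2 to compound 3 (0.21 log units; that floor lies within the scatter), so this change, too, shows no firm direction. The step from compound 1 to compound 3 cannot be read, and the picture at this position rests largely on one limit: the limit of > 20000 nM in this assay, at which 2 of the 3 values shown sit.

All three groups shown here are aromatic rings, so it remains open whether an amine, a carboxylic acid or a short alkyl chain on this carbon would give a number clearly apart from these results. Going by these compounds, it also remains open whether a pyridine ring would differ from furan-3-yl by more than the scatter.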